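Trading the amide of compound 2 for a nitrile

The source may hold more compounds than are shown below. What is called first, only, known or untested is meant among the compounds shown, and "the series" means these compounds.

Compound 1 `OC12CCCC3CC(CCC31)C2` and compound 2 `CNC(=O)C12CCCC3CC(CCC31)C2` share a saturated tricyclic core. Within the data shown here, in an ADME assay (Gallus gallus) for cytotoxicity, read by microscopy, with a stated time of 24 h (a higher number here means that more compound is tolerated, a lower number that less compound is tolerated), compound 1 gives 6000000 nM, while compound 2 gives 750000 nM, the lowest of the two numbers; the one step, an 8.0-fold lower number from compound 1 to compound 2 (0.90 log units; beyond the scatter), is modest. Compound 3 `N#CC12CCCC3CC(CCC31)C2` differs from compound 2 by cyano in place of methylcarbamoyl on a saturated ring carbon. Among the measured compounds shown here, no measured step concerns this change, so the expectation rests only on the small size of the remaining group. The expected change is a 1.3-fold higher number from compound 2 to compound 3 (0.12 log units; within the scatter), modest if any. For compound 3 in this assay the estimate is 1000000 nM, from 300000 nM to 4000000 nM.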

Compound 3, minimum cytotoxic concentration: 850000 nM
Compound 3: middle estimate off by 1.2-fold (0.07 log units), on the high side, within the range that was stated.
By their numbers in this assay, from the lowest: compounds 2 and 3 (each within the scatter of the next); then compound 1.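

In this assay, cyano in place of methylcarbamoyl on this saturated ring carbon gives a 1.1-fold higher number from compound 2 to compound 3 (0.05 log units; within the scatter), so the two groups cannot be told apart here, even though cyano has fewer heavy atoms and no hydrogen-bond donor. Cyano in place of hydroxy gives a 7.1-fold lower number from compound 1 to compound 3 (0.85 log units; beyond the scatter), which leaves compound 1 apart from both compound 2 and compound 3. No available evidence accounts for these numbers. Still open, on these data alone, is whether an amine, a carboxylic acid or a longer chain on this carbon would fall with hydroxy or with the other two groups.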